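Chloro to methyl on a chloromethyl ketone ester

A few compounds are considered here, and "the series" means these few. Any claim that something is new, unique, unknown or untested is made for them only; others in the source may bear on it.

Among the measured compounds shown here, compound 1 `CCCCCC[C@@H](C)OC(=O)CC(=O)CCl` is the only compound with a number in an assay on isolated protein for inhibition of Fatty-acid amide hydrolase 1 (Homo sapiens), at pH 9.0 (a higher number here means a weaker inhibitor, a lower number a stronger inhibitor), where compound 1 gives 2900 nM. Compound 2 `CCCCCC[C@H](C)OC(=O)CC(C)=O` reaches only a limit of this assay, with compound 2 at > 100000 nM. Compound 3 `CCCCCC[C@@H](C)OC(=O)CC(=O)CC` differs from compound 1 by methyl in place of chloro on a saturated chain carbon bound to a carbonyl carbon. Given (the limit of > 100000 nM in this assay, at which 1 of the 2 values shown sits), a large loss is expected in this assay, the step from compound 1 to compound 3 being estimated at a 21-fold higher number from compound 1 to compound 3 (1.32 log units; beyond the scatter). Compound 3 is expected at 60000 nM, between 15000 nM and 200000 nM.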

Compound 3, half-maximal inhibitory concentration: > 100000 nM
Compound 3 was reported as a limit; the forecaster's own chance of this, stated with the estimate: 50%; at least 1.6-fold (0.22 log units) between middle value and limit.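

Among the compounds shown here, this is the first step in the set that changes one place only: keeping the rest of compound 1, methyl in place of chloro on a saturated chain carbon bound to a carbonyl carbon gives an at least 34-fold higher number from compound 1 to compound 3 (1.53 log units; beyond the scatter). The value of compound 3, > 100000 nM, is a limit of this assay and not a number. Among the compounds shown, a numerical value at this position therefore goes with chloro, not methyl. On these data alone, it remains open whether fluoro, bromo or hydroxyl at this place would give a numerical value, and what a longer chain on the ester would do.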